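The source may report more compounds than this note shows. Statements on the series, on what has been measured and on what is new or still open speak of the compounds shown alone.

Compound 1 `CCn1cc(-c2nc3ccccc3[nH]2)c(=O)c2cc(F)c(N3CCNCC3)cc21` gives 27400 nM in a functional assay on Bel-7402 cells (Homo sapiens) for cytotoxicity, read by MTT assay, with a stated time of 48 h; a lower number here means a stronger inhibitor, a higher number a weaker inhibitor.
Compound 2 `CCn1cc(-c2nc3ccccc3o2)c(=O)c2cc(F)c(Cl)cc21` gives 28900 nM in this assay.
Compound 3 `CCn1cc(-c2nc3ccc([N+](=O)[O-])cc3[nH]2)c(=O)c2cc(F)c(N3CCNCC3)cc21` gives 2100 nM in this assay.

Compound 1 and compound 3 differ in one place only: nitro in place of hydrogen on an aromatic carbon. This single change gave a 13-fold lower number from compound 1 to compound 3 (1.12 log units; beyond the scatter), a clear gain in cytotoxic potency.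

Compound 2 has a different core from compound 1; how the two cores differ is not broken down here. Their values in this assay lie within the scatter of each other, so nothing separates them.

Compound 4 `CCn1cc(-c2nc3ccc([N+](=O)[O-])cc3o2)c(=O)c2cc(F)c(Cl)cc21` has not yet been measured. It is built from compound 2 by nitro in place of hydrogen on an aromatic carbon, the same kind of change as that from compound 1 to compound 3, and at the same kind of place. Because the earlier change gave a 13-fold lower number from compound 1 to compound 3 (1.12 log units; beyond the scatter), a step of similar size is expected here, although the core is a different one and the change has been seen only once. For compound 4 the expected step is an 8.3-fold lower number from compound 2 to compound 4 (0.92 log units; beyond the scatter). Compound 4 is therefore estimated at 3500 nM, most likely between 1200 nM and 12000 nM.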

Compound 4, half-maximal inhibitory concentration: 1800 nM
The estimate for compound 4 lay 1.9-fold (0.29 log units) above the measured number; the range from low to high includes it.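

Nitro in place of hydrogen on an aromatic carbon again lowered the number sharply in this assay, with a 16-fold lower number from compound 2 to compound 4 (1.21 log units; beyond the scatter). Set beside the earlier step, the change kept its size when carried from the core of compound 1 to the core of compound 2: the same change on two cores in this assay, a 13-fold lower number (1.12 log units; beyond the scatter) from compound 1 to compound 3 and a 16-fold lower number (1.21 log units; beyond the scatter) from compound 2 to compound 4, 1.2-fold (0.09 log units) apart, within the scatter of two such steps. This shows that the two cores agree for this one change in this one cell assay; it does not show why the nitro group has this effect, or that a third core or another cell line would respond in the same way.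

The compounds shown leave open whether the gain belongs to the nitro group itself or would also come with another group on the same carbon, such as an amine, a nitrile or a carboxylic acid. They also leave open what a nitro group on another carbon of that six-membered ring would do.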